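Swapping a cyanofuran for a cyanophenyl on the shared core

The source may report more compounds than this note shows. Statements on the series, on what has been measured and on what is new or still open speak of the compounds shown alone.

Measured so far:
compound 1 `N#Cc1ccc(-c2nc(N)c3cc(Cc4ccccc4)sc3n2)o1` gives 3160 nM
compound 2 `Cc1csc(-c2nc(N)c3cc(Cc4ccccc4Cl)sc3n2)n1` gives 49.6 nM
compound 3 `Nc1nc(-c2ccccc2)nc2sc(-c3ccccc3)cc12` gives 237 nM

All three numbers come from a functional assay on CHO-K1 cells for antagonist activity at adenosine receptor A1 (Homo sapiens), read by a beta-galactosidase reporter and cAMP accumulation, with stated times of 15 min and 6 h; a lower number here means a stronger inhibitor, a higher number a weaker inhibitor. Compound 1 stands at the highest of the three numbers, that is, it is the weakest inhibitor here. Its nearest neighbour in value is compound 3, whose number is lower by a margin beyond the scatter, and the furthest is compound 2, lower still.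

The next compound, compound 4 `N#Cc1cccc(-c2nc(N)c3cc(Cc4ccccc4)sc3n2)c1`, has not been measured in this assay. It differs from compound 1 in one place: 3-cyanophenyl in place of 5-cyanofuran-2-yl on an aromatic carbon

No measured pair differs in exactly this way, so the expected step rests on what the shared core has shown. Compound 3, which carries a plain phenyl ring at this same place, gives 237 nM, and compound 1 with its cyanofuran gives 3160 nM; this suggests a six-membered carbon ring here may be tolerated better. A moderate step downwards, toward a stronger inhibitor, is therefore expected from compound 1 to compound 4 a 2.9-fold lower number from compound 1 to compound 4 (0.46 log units; beyond the scatter), though compound 3 also differs elsewhere, so the expectation is loose. For compound 4 the estimate in this assay is 1100 nM, with a range from 300 nM to 4000 nM.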

Compound 4, inhibition constant: 222 nM
Beside the measured number, compound 4's estimate is 5.0-fold (0.70 log units) above it; the whole stated range lies above it.
By their numbers in this assay, from the lowest: compound 2; then compounds 4 and 3 (each within the scatter of the next); then compound 1.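

In this assay, among the compounds shown here, putting 3-cyanophenyl in place of 5-cyanofuran-2-yl gives a 14-fold lower number from compound 1 to compound 4 (1.15 log units; beyond the scatter), the only comparison here in which the two compounds differ in a single place. It shows that the group on this aromatic carbon, between two ring nitrogen atoms, has a large influence on this read-out, even though both groups carry a nitrile. The data give no reason for the size of this step.

Going by these compounds, the change replaces the ring and moves the nitrile at once, so the contribution of each remains open. A pair such as 4-cyanophenyl and unsubstituted furan-2-yl on this same core would help separate them, and a pyridine ring or a 3-methoxyphenyl would test whether the nitrile can be replaced.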